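A Methoxyphenyl for a Fluorophenyl on a Shared Core

The compounds below may be only part of what the source reports. "The series", "measured", "known", "first", "only" and "open" are said of these compounds alone.

Of the compounds shown here, two built on a shared core have been measured in an ADME assay on Vero cells (Chlorocebus sabaeus) for cytotoxicity, read by MTT assay; on this read-out higher numbers stand for weaker inhibition and lower numbers for stronger inhibition. Compound 1 `C=CCOc1cc(OC)c(C(=O)/C=C/c2cc(OC)c(OC)c(OC)c2)c(OCC=C)c1` gives 40900 nM in this assay, and compound 2 `C=CCOc1cc(OC)c(C(=O)/C=C/c2ccccc2F)c(OCC=C)c1` gives 16300 nM. Compound 2 therefore holds the lowest of the two numbers; its nearest neighbour is compound 1, whose number sits higher by a margin beyond the usual scatter.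

Compound 3 `C=CCOc1cc(OC)c(C(=O)/C=C/c2ccc(OC)cc2)c(OCC=C)c1` has not yet been measured. It differs from compound 2 in a single place: 4-methoxyphenyl in place of 2-fluorophenyl on a double-bonded chain carbon bound to a double-bonded chain carbon. Among the measured compounds shown here, no pair of measured compounds shows this change, so any expectation rests only on compound 1 and compound 2. A modest upward step a 1.5-fold higher number from compound 2 to compound 3 (0.19 log units; within the scatter) is expected, probably within the scatter or only just beyond it, because methoxy-bearing compound 1 gives 40900 nM. For compound 3 the estimate in this assay is 25000 nM, with a range from 10000 nM to 60000 nM.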

Compound 3, half-maximal inhibitory concentration: 99900 nM
Compound 3: the middle estimate sits 4.0-fold (0.60 log units) below what was measured; measured number above the stated range.
By their numbers in this assay, from the lowest: compound 2; then compound 1; then compound 3.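

In this assay the group on a double-bonded chain carbon bound to a double-bonded chain carbon can move the number a long way: 4-methoxyphenyl in place of 2-fluorophenyl gives a 6.1-fold higher number from compound 2 to compound 3 (0.79 log units; beyond the scatter) and leaves compound 3 with the highest number of the three. A methoxy-bearing group at this place does not fix the number by itself, since compound 1 gives 40900 nM while compound 3 gives 99900 nM in the same assay. Nothing at hand explains the size of this step.

The compounds shown leave open whether the step follows from losing the fluorine, gaining the methoxy, or where each sits on the ring. From the compounds shown here alone, a plain phenyl, a 4-fluorophenyl or a 2-methoxyphenyl at this place could separate these, and how a phenyl bearing an amine would read also remains open.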